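Replacing a Trifluoromethylphenyl Ring with Benzyl in a Quinoline Series

The compounds below may be only part of what the source reports. "The series", "measured", "known", "first", "only" and "open" are said of these compounds alone.

Three compounds share a core and differ only in the group on a saturated chain carbon bound to an amine nitrogen. In an ADME assay for permeability, using PAMPA, with a stated time of 30 min, at pH 7.4 (a lower number here means that the compound crosses the layer more slowly, a higher number that the compound crosses the layer faster), compound 1 `COc1cccc(CNCCCNc2ccnc3cc(Cc4cccc(C(F)(F)F)c4)ccc23)c1O` gives 23 10^-6 cm/s, compound 2 `COc1ccc(F)cc1CNCCCNc1ccnc2cc(Cc3cccc(C(F)(F)F)c3)ccc12` gives 23 10^-6 cm/s and compound 3 `FC(F)(F)c1cccc(Cc2ccc3c(NCCCNCc4ccco4)ccnc3c2)c1` gives 23 10^-6 cm/s. The steps of no change at the digits printed from compound 1 to compound 2 (within the scatter), no change at the digits printed from compound 1 to compound 3 (within the scatter) and no change at the digits printed from compound 2 to compound 3 (within the scatter) all lie within the scatter, so compound 2 stands level with the other two. Compound 4 `COc1ccc(F)cc1CNCCCNc1ccnc2cc(CCc3ccccc3)ccc12` differs from compound 2 by benzyl in place of 3-(trifluoromethyl)phenyl on a saturated chain carbon bound to an aromatic carbon. Going by the values given here, no measured step touches this part of the molecule, so the three steps offer no direct guide. Compound 4 is therefore expected to give 18 10^-6 cm/s (range 9 10^-6 cm/s to 35 10^-6 cm/s) in this assay, meaning an estimated step of a 1.3-fold lower number from compound 2 to compound 4 (0.11 log units; within the scatter) that stays within the scatter.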

Compound 4, apparent permeability: 23 10^-6 cm/s
Beside the measured number, compound 4's estimate is 1.3-fold (0.11 log units) below it; the measured number falls inside the stated range.
By their numbers in this assay, from the lowest: compounds 1, 2, 3 and 4 (each within the scatter of the next).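

Going by these compounds alone, the earlier steps all changed the group on the amine side, whereas this one is the first to change the group on a saturated chain carbon bound to an aromatic carbon. In this assay, benzyl in place of 3-(trifluoromethyl)phenyl gives no change at the digits printed from compound 2 to compound 4 (within the scatter), so this swap, which removes the trifluoromethyl group, leaves the read-out level. Nothing available explains this result.

This single pair leaves open whether an amine or a carboxylic acid at this position would also leave the number level. It also leaves open whether the same swap behaves alike with furan-2-yl on the amine side.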